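Trading Bromo for Hydrogen at the Assay Limit

The compounds below may be only part of what the source reports. "The series", "measured", "known", "first", "only" and "open" are said of these compounds alone.

In a functional assay on HCT-116 cells (Homo sapiens) for cytotoxicity, read by MTT assay, with a stated time of 72 h (a lower number here means a stronger inhibitor, a higher number a weaker inhibitor), compound 2 `NCCCNc1c(C(=O)NCc2ccc(F)cc2)nc(Br)c2cccnc12` gives > 20000 nM, which is a limit and not a number. Compound 1 `CS(=O)(=O)Oc1c(C(=O)NCc2ccc(F)cc2)nc(Br)c2cccnc12` gives > 20000 nM, also a limit. Compound 3 `Cc1ccc(S(=O)(=O)Oc2c(C(=O)NCc3ccc(F)cc3)nc(Br)c3cccnc23)cc1` gives > 20000 nM, again a limit. For the measured compounds named here, the series so far therefore shows (the limit of > 20000 nM in this assay, at which 3 of the 3 values shown sit).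

Compound 4 `NCCCNc1c(C(=O)NCc2ccc(F)cc2)ncc2cccnc12` differs from compound 2 in one place: hydrogen in place of bromo on an aromatic carbon. Hydrogen stands in place of bromo on an aromatic carbon, para to the (3-aminopropyl)amino group.

Going by the values given here, none of the measured steps changes the bromo, and none has a size that can be read. One is a step that the two limits leave unreadable from compound 1 to compound 2, another is a step that the two limits leave unreadable from compound 1 to compound 3, and the third is a step that the two limits leave unreadable from compound 2 to compound 3. Among the compounds with values here, the only anchor is compound 2 at > 20000 nM, a limit, so no step beyond the usual scatter is expected. The estimated change is a number no higher from compound 2 to compound 4 (the limit leaves the size open). For compound 4 the expected value is 20000 nM, with an estimated range from 7000 nM to 40000 nM.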

Compound 4, half-maximal inhibitory concentration: > 10000 nM
Compound 4 ended at the assay's limit; the forecaster's own chance of this, stated with the estimate: 65%; the middle value is on the limit's open side.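

In this assay compound 4 gives > 10000 nM, which is a limit and not a number. Compound 2 gives > 20000 nM, also a limit, so no new step can be read between compound 2 and compound 4. As far as these compounds go, what hydrogen in place of bromo does to cytotoxicity stays open.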